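Swapping chloro for fluoro in a low-inhibition series

A few compounds are considered here, and "the series" means these few. Any claim that something is new, unique, unknown or untested is made for them only; others in the source may bear on it.

In a functional assay on Bel-7402 cells (Homo sapiens) for inhibition, read by MTT assay, with a stated time of 24 h, tested at 10 ug/mL (a higher number here means more inhibition of growth at the concentration tested, a lower number less inhibition of growth), three compounds with a shared core have been measured so far. Compound 1 (`O=C(CCCCC(S)CCS)Nc1ccccc1`) gives 3.72% of inhibition, compound 2 (`O=C(CCCCC(S)CCS)Nc1ccccc1Cl`) is reported as "not active" (no number reported) with no number attached, and compound 3 (`O=C(CCCCC(S)CCS)Nc1ccc(Cl)cc1`) gives 1.16% of inhibition. Compound 3 therefore sits at the low end of the scale, within the scatter of compound 1, so neither can be ranked above the other.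

Compound 4 (`O=C(CCCCC(S)CCS)Nc1ccc(F)cc1`) differs from compound 3 at one place (fluoro in place of chloro on an aromatic carbon) with fluoro in place of chloro on an aromatic carbon. Going by the values given here, no measured step makes this exact swap. The expectation therefore rests on the nearest evidence, a number 2.6 percentage points lower from compound 1 to compound 3 (within the scatter) for chloro in place of hydrogen on an aromatic carbon, and no step beyond the scatter is expected in this assay in either direction. A report with no number, as for compound 2, would also fit this expectation. The estimated change is a number 0.8 percentage points higher from compound 3 to compound 4 (within the scatter) and this stays within the usual noise. For compound 4 the expected inhibition is 2% with an estimated range from 0% to 10% at the tested concentration.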

Compound 4, percent growth inhibition at one concentration: 6.14%
The estimate for compound 4 lay 4.1 percentage points below the measured number; measured number inside the range.
By their numbers in this assay, from the lowest: compounds 3, 1 and 4 (each within the scatter of the next).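

In this assay, fluoro in place of chloro gives a number 5 percentage points higher from compound 3 to compound 4 (within the scatter), and fluoro in place of hydrogen at the same aromatic carbon gives a number 2.4 percentage points higher from compound 1 to compound 4 (within the scatter). Together with the earlier step for chloro in place of hydrogen, a number 2.6 percentage points lower from compound 1 to compound 3 (within the scatter), this closes the set: hydrogen, chloro and fluoro at this place, para to a large group, cannot be ranked against one another, and the change of halogen shows no effect that stands clear of the usual noise. Nothing in the data shown offers an explanation for these small differences.

The compounds shown leave open whether a quite different group on this aromatic carbon, such as an amine or a carboxylic acid, would produce a step beyond the scatter. They also leave open whether a longer chain in the shared core would lift inhibition, since every compound here carries the same chain and only the aromatic substituent varies.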